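Swapping the Furan Amide for a Fluorophenyl Amide

This account rests on a few compounds, and the source may have more. Where it says the series, first, only, none or still open, it means among the compounds named here.

Measured so far:
compound 1 `COc1ccc(-c2cnc(NC(=O)c3ccco3)n2C)cc1`: > 100000 nM
compound 2 `Cc1ccc(C(=O)Nc2ncc(-c3ccccc3)o2)cc1`: 26000 nM
compound 3 `Cc1ccc(-c2cnc(NC(=O)c3ccc(F)cc3)n2C)cc1`: 60000 nM

Of the compounds shown here, three have been tested in a toxicity assay on THP-1 cells (Homo sapiens) for inhibition; a higher number here means that more compound is tolerated, a lower number that less compound is tolerated. In this assay compound 1 reaches only the limit of the assay, > 100000 nM, so its value is not a number (the limit of > 100000 nM in this assay, at which 1 of the 3 values shown sits). In this assay compound 2 gives 26000 nM, and compound 3 gives 60000 nM. No two of these compounds differ in a single place, so no step between them has been measured.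

Compound 4 `COc1ccc(-c2cnc(NC(=O)c3cccc(F)c3)n2C)cc1` has not yet been tested. Compared with compound 1 it carries 3-fluorophenyl in place of furan-2-yl on a carbonyl carbon. Compound 3, which gives 60000 nM in this assay, shows that a measurable number can be obtained with an amide of this kind, and compound 4 is expected to behave likewise. In this assay the step from compound 1 to compound 4 is expected to be small and towards less compound tolerated, an at least 1.4-fold lower number from compound 1 to compound 4 (0.15 log units; that floor lies within the scatter). For compound 4 the expected value in this assay is 70000 nM, with a range from 30000 nM to 150000 nM.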

Compound 4, half-maximal cytotoxic concentration: > 100000 nM
Compound 4: a limit, no number; the forecaster's own chance of this, stated with the estimate: 40%; at least 1.4-fold (0.15 log units) between middle value and limit.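

No step can be read from compound 1 to compound 4, since in this assay both give a limit and not a number: the limit of > 100000 nM in this assay, at which 2 of the 4 values shown sit.

The compounds shown leave open whether 3-fluorophenyl in place of furan-2-yl on a carbonyl carbon changes how much compound is tolerated.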